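Compound 4: a second furan-2-yl group replaces a phenyl

The compounds below may be only part of what the source reports. "The series", "measured", "known", "first", "only" and "open" are said of these compounds alone.

Of the compounds shown here, three built on a shared core have been measured in an ADME assay on HEK-293T cells (Homo sapiens) for cytotoxicity, read by MTT assay, with a stated time of 72 h, tested at 50 uM; a higher number here means more inhibition at the concentration tested (going by the name of the read-out), a lower number less inhibition. Compound 1 `O=C(Cn1c(-c2ccccc2)cc(-c2ccccc2)c1-c1ccco1)Nc1nc2ccccc2s1` gives 89.9%, the highest of the three numbers. Compound 2 `O=C(Cn1c(-c2ccccc2)cc(-c2ccccc2)c1-c1ccco1)NCc1ccccc1`, with benzyl in place of 1,3-benzothiazol-2-yl on an amide-type nitrogen, gives 72.4%, and that step, a number 17.5 percentage points lower from compound 1 to compound 2 (beyond the scatter), is modest. Compound 3 `O=C(Cn1c(-c2ccccc2)cc(-c2ccccc2)c1-c1ccccc1)Nc1nc2ccccc2s1`, with phenyl in place of furan-2-yl on an aromatic carbon, gives 55%, and that step, a number 34.9 percentage points lower from compound 1 to compound 3 (beyond the scatter), is large. Both of the other compounds therefore lie beyond the scatter below compound 1.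

Compound 4 `O=C(Cn1c(-c2ccccc2)cc(-c2ccco2)c1-c1ccco1)Nc1nc2ccccc2s1` has not yet been measured in this assay. It differs from compound 1 in one place: furan-2-yl in place of phenyl on an aromatic carbon. For the measured compounds named here, of the two measured steps, only the one from compound 1 to compound 3 bears on this change, since it swaps the same two groups, phenyl and furan-2-yl, on an aromatic carbon of the same core, though at a different place and in the opposite direction. That step was large and downward when phenyl entered, so furan-2-yl entering in compound 4 is expected to move the number upward, or at most to leave it within the scatter, because compound 1 already gives 89.9% and little room remains above it. Compound 4 is therefore expected to give 92%, with a range from 78% to 100%, a step of a number 2.1 percentage points higher from compound 1 to compound 4 (within the scatter).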

Compound 4, a percentage reported as inhibition, at one concentration (the size of the read-out at that concentration, not a potency): 65.1%
Estimate against measurement, compound 4: 26.9 percentage points above; the whole stated range lies above it.
By their numbers in this assay, from the lowest: compound 3; then compounds 4 and 2 (each within the scatter of the next); then compound 1.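

In this assay, furan-2-yl in place of phenyl on this aromatic carbon, two ring bonds from the ring nitrogen, gives a number 24.8 percentage points lower from compound 1 to compound 4 (beyond the scatter), so adding a second furan-2-yl group here does not raise the number as the earlier exchange of the same two groups elsewhere on the core might have suggested. Together with a number 34.9 percentage points lower from compound 1 to compound 3 (beyond the scatter), this shows that the effect of exchanging phenyl and furan-2-yl depends on where the exchange is made: compound 1, with one furan-2-yl group and two phenyl groups, lies above both compound 3 and compound 4, and each of these one-place changes takes the number down beyond the scatter. Nothing is available that would explain why the two places differ in this way.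

The compounds shown leave open whether a different ring at this position, such as thiophen-2-yl or pyridin-3-yl, or a small group such as methyl, would keep the number near that of compound 1. They also leave open whether the same fall would appear with benzyl on the amide nitrogen, as in compound 2, rather than 1,3-benzothiazol-2-yl.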